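A few compounds are considered here, and "the series" means these few. Any claim that something is new, unique, unknown or untested is made for them only; others in the source may bear on it.

Three compounds have so far been examined in a functional assay on COLO 320 cells (Homo sapiens) for cytotoxicity, read by WST assay, with a stated time of 72 h; on this read-out lower numbers stand for stronger inhibition and higher numbers for weaker inhibition. Compound 1 `COc1ccc(-c2cc(-c3cc4ccccc4n3C)no2)cc1` returns only a limit of the assay rather than a number, > 100000 nM. Compound 2 `COc1cccc(-c2cc(-c3cc4cc(OC)ccc4[nH]3)no2)c1` likewise stops at a limit, > 100000 nM. Both of these entries rest at the limit of > 100000 nM in this assay, at which 2 of the 3 values shown sit, so they say nothing about how weak the compounds truly are. Among the measured compounds shown here, compound 3 `Fc1ccc(-c2cc(-c3ccc4[nH]ccc4c3)on2)cc1` stands apart: in this assay compound 3 gives 13900 nM, the only actual number in the set, and it is therefore the single anchor from which any expectation can be built.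

Compound 4 `O=[N+]([O-])c1ccc(-c2cc(-c3ccc4[nH]ccc4c3)on2)cc1` is the next compound to be tested. It differs from compound 3 in one place: nitro in place of fluoro on an aromatic carbon. The fluoro group on the six-membered aromatic ring of carbon only, para to a large group, is exchanged for a nitro group. For the measured compounds named here, no measured pair in this set differs in only one place, so no comparable step is available to lean on. The step of a 1.4-fold lower number from compound 3 to compound 4 (0.14 log units; within the scatter) is therefore expected to be modest, probably within the usual scatter, with at most a slight shift toward stronger inhibition. Compound 4 is estimated to give 10000 nM, with a likely range from 3000 nM to 40000 nM.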

Compound 4, half-maximal inhibitory concentration: 14000 nM
For compound 4 the middle estimate is 1.4-fold (0.15 log units) below the measured one, within the range that was stated.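

In this assay, putting nitro in place of fluoro on the six-membered aromatic ring of carbon only, para to a large group, gives a 1.0-fold higher number from compound 3 to compound 4 (0.00 log units; within the scatter). Among the compounds shown here, this is the first comparison in the set between two compounds that differ in only one place, so it is the first direct look at this position. It shows that a single fluorine can give way to a nitro group, with three heavy atoms and two hydrogen-bond acceptors, while the two compounds still read alike, and nothing measured here explains why they do.

For the compounds shown here, only two groups have been compared at this position, so it remains open whether an amine, a carboxylic acid or a longer chain in the same place would also read alike or would move the number clearly in either direction. Going by these compounds alone, compound 1 and compound 2 differ from compound 3 in more than one place, so it also remains open whether this exchange of fluoro for nitro would read the same way on a core other than the one shared by compound 3 and compound 4.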